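Triazole-linked bicyclic lactams: aryl swap from compound 2

A few compounds are considered here, and "the series" means these few. Any claim that something is new, unique, unknown or untested is made for them only; others in the source may bear on it.

Of the compounds shown here, three of the shared core have been measured in a functional assay on LoVo cells (Homo sapiens) for inhibition, read by MTT assay, with a stated time of 24 h; a higher number here means a weaker inhibitor, a lower number a stronger inhibitor. Compound 1 `CC1(C)[C@H]2CC[C@]1(C)N(Cc1cn(-c3ccccc3C#N)nn1)C(=O)C2` gives 140 nM, compound 2 `CC1(C)[C@H]2CC[C@]1(C)N(Cc1cn(-c3cccc(C#N)c3)nn1)C(=O)C2` gives 320 nM, and compound 3 `CC1(C)[C@H]2CC[C@]1(C)N(Cc1cn(-c3ccc(Cl)cc3)nn1)C(=O)C2` gives 160 nM. Compound 2 carries the highest of the three numbers; its nearest neighbour is compound 3, with a 2.0-fold lower number from compound 2 to compound 3 (0.30 log units; within the scatter), while compound 1 lies further off, with a 2.3-fold higher number from compound 1 to compound 2 (0.36 log units; beyond the scatter).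

Compound 4 `COc1ccc(-n2cc(CN3C(=O)C[C@@H]4CC[C@@]3(C)C4(C)C)nn2)cc1` is not yet measured. It differs from compound 2 in one place: 4-methoxyphenyl in place of 3-cyanophenyl on an aromatic nitrogen. Among the measured compounds shown here, the step that bears most on it is the one from compound 2 to compound 3, where a 4-chlorophenyl also replaced the 3-cyanophenyl and gave a 2.0-fold lower number from compound 2 to compound 3 (0.30 log units; within the scatter); the only step printed as beyond the scatter is a 2.3-fold higher number from compound 1 to compound 2 (0.36 log units; beyond the scatter), in the opposite sense. No 4-methoxyphenyl has been measured in this series, so the expectation leans on compound 3 alone. Compound 4 is therefore expected to show a 1.6-fold lower number from compound 2 to compound 4 (0.20 log units; within the scatter) in this assay, a modest move towards a lower number or none beyond the scatter. The estimate for compound 4 is 200 nM, with a range from 90 nM to 450 nM.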

Compound 4, half-maximal inhibitory concentration: 70 nM
For compound 4 the middle estimate is 2.9-fold (0.46 log units) above the measured one; measured number outside the range, below it.
By their numbers in this assay, from the lowest: compounds 4, 1, 3 and 2 (each within the scatter of the next, the first and the last beyond it).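

Among the compounds shown here, on this aromatic nitrogen, the aryl group can shift the number in this assay by more than the first three compounds showed: 4-methoxyphenyl in place of 3-cyanophenyl gives a 4.6-fold lower number from compound 2 to compound 4 (0.66 log units; beyond the scatter), the largest step so far. The result also separates two groups on the same phenyl framework, since methoxy in place of chloro gives a 2.3-fold lower number from compound 3 to compound 4 (0.36 log units; beyond the scatter), whereas 4-chlorophenyl and 3-cyanophenyl had stayed within the scatter of each other. Compound 4 still cannot be separated from the 2-cyanophenyl analogue, with a 2.0-fold lower number from compound 1 to compound 4 (0.30 log units; within the scatter). Nothing shown here accounts for these differences.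

Still open, from the compounds shown here alone, is whether the methoxy group depends on where it sits, which 2-methoxyphenyl and 3-methoxyphenyl would test. Also open, going by these compounds, is whether a 4-ethoxyphenyl or 4-aminophenyl group would extend the step or reverse it.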